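The source may hold more compounds than are shown below. What is called first, only, known or untested is meant among the compounds shown, and "the series" means these compounds.

Measured compounds:
compound 1 `COc1ccccc1N1CCN(CCCn2c(=O)[nH]c3cc[nH]c3c2=O)CC1` gives 28 nM
compound 2 `O=c1[nH]c2cc[nH]c2c(=O)n1CCCN1CCN(c2ccccc2Cl)CC1` gives 59.8 nM
compound 3 `COc1ccccc1N1CCN(CCn2c(=O)[nH]c3cc(-c4ccccc4)[nH]c3c2=O)CC1` gives 0.52 nM

In an assay for binding affinity to Adrenergic receptor alpha-1 (Rattus norvegicus) (a lower number here means a stronger inhibitor, a higher number a weaker inhibitor), compound 1 stands second highest of the three numbers. Its nearest neighbour is compound 2, reached by a 2.1-fold higher number from compound 1 to compound 2 (0.33 log units; beyond the scatter). Its furthest is compound 3, which holds the lowest number of the set.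

Compound 4 `COc1ccccc1N1CCN(CCCn2c(=O)[nH]c3cc(-c4ccccc4)[nH]c3c2=O)CC1` differs from compound 1 by phenyl in place of hydrogen on an aromatic carbon. Among the compounds with values here, the only measured step, a 2.1-fold higher number from compound 1 to compound 2 (0.33 log units; beyond the scatter), concerns the chloro-for-methoxy exchange and does not bear on the phenyl. Within the data shown here, compound 3 carries the same phenyl on the core, but it differs from compound 1 at a second site as well, so no single step separates the two; its value shows only that the pair of changes together brings the number far down from compound 1.

On that basis a large downward step is expected, a 19-fold lower number from compound 1 to compound 4 (1.27 log units; beyond the scatter). Compound 4 is estimated at 1.5 nM in this assay, within 0.4 nM to 6 nM.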

Compound 4, inhibition constant: 1.23 nM
The estimate for compound 4 lay 1.2-fold (0.09 log units) above the measured number; measured number inside the range.
By their numbers in this assay, from the lowest: compound 3; then compound 4; then compound 1; then compound 2.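

In this assay, the phenyl on the aromatic carbon of the five-membered ring, next to the ring nitrogen, now stands alone as a single change, and it gives a 23-fold lower number from compound 1 to compound 4 (1.36 log units; beyond the scatter). Within the data shown here, until now this phenyl had been seen only in compound 3, together with a different chain; with compound 4 at 1.23 nM and compound 3 at 0.52 nM, most of the distance from compound 1 is reached with the phenyl alone. No measurement here bears on what lies behind this step.

Open, from the compounds shown here alone, is whether a small group such as methyl, or a pyridyl ring, at this carbon would give a comparable step, and whether substituents on the phenyl would change it. Also open, going by these compounds, is whether chloro in place of methoxy gives a similar step when the phenyl is present.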